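Bromo for Chloro: What to Expect of Compound 4

A few compounds are considered here, and "the series" means these few. Any claim that something is new, unique, unknown or untested is made for them only; others in the source may bear on it.

Compound 1 `CC1(C)CC(=O)C(C(=S)SCc2ccccc2)=C(Nc2ccc(Cl)cc2)C1`: in a functional assay on PBMC cells (Homo sapiens) for inhibition, read by ELISA, with a stated time of 18 h (on this read-out higher numbers stand for weaker inhibition and lower numbers for stronger inhibition), compound 1 gives > 20 ug/mL, which is a limit of the assay and not a number.
Compound 2 `CC(=O)OC[C@H]1O[C@@H](SC(=S)C2=C(Nc3ccc(Cl)cc3)CC(C)(C)CC2=O)[C@H](OC(C)=O)[C@@H](OC(C)=O)[C@@H]1OC(C)=O`: here compound 2 gives 3.5 ug/mL.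
Compound 3 `CC1(C)CC(=O)C(C(=S)SCc2ccccc2)=C(Nc2ccc(Br)cc2)C1`: compound 3 gives > 20 ug/mL, again a limit rather than a number.

Compound 3 differs from compound 1 by bromo in place of chloro on an aromatic carbon. The resulting step, a step that the two limits leave unreadable from compound 1 to compound 3, cannot be sized, because the limit of > 20 ug/mL in this assay, at which 2 of the 3 values shown sit, holds both ends of it. Compound 2 carries the same change as compound 4 will, but how its core differs from that of compound 1 is not broken down here; compound 2 is the only one of the three with a number rather than a limit.

Compound 4 `CC(=O)OC[C@H]1O[C@@H](SC(=S)C2=C(Nc3ccc(Br)cc3)CC(C)(C)CC2=O)[C@H](OC(C)=O)[C@@H](OC(C)=O)[C@@H]1OC(C)=O` is not yet measured. It differs from compound 2 by bromo in place of chloro on an aromatic carbon, the same change, at the same place, as from compound 1 to compound 3. Since that measured step is unreadable, nothing here points to a shift of either direction, and a small step of no change at the digits printed from compound 2 to compound 4 (within the scatter) is expected. Compound 4 is therefore estimated at 3.5 ug/mL, within 1.5 ug/mL to 8 ug/mL.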

Compound 4, half-maximal inhibitory concentration: 3.4 ug/mL
Compound 4: middle estimate off by 1.0-fold (0.01 log units), on the high side, and the stated range covers the measured number.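

In this assay, bromo in place of chloro on the core of compound 2 gives a 1.0-fold lower number from compound 2 to compound 4 (0.01 log units; within the scatter), so on this core the two halogens cannot be told apart. The same change on the core of compound 1 cannot be read, as compound 1 and compound 3 both sit at a limit and not at a number: the limit of > 20 ug/mL in this assay, at which 2 of the 4 values shown sit. The result therefore gives one readable case of the swap on one core, and it does not show that the change behaves alike on both cores, since a step with no readable size cannot be set against it.

The compounds shown carry only chloro and bromo on the aromatic ring, so what fluoro, a methoxy group or an amine in that place would give stays open. How the same swap reads on a third core, or on the core of compound 1 with numbers at both ends, is open as well.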